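Half-life on Mouse Liver Microsomes: Rearranging the Side Chain

The source may hold more compounds than are shown below. What is called first, only, known or untested is meant among the compounds shown, and "the series" means these compounds.

Measured compounds:
- compound 1 `Cc1cc(C(=O)Nc2ccc(Cl)cc2)ccc1N(CCN1CCCC1=O)C(=O)Nc1ccc(Cl)cc1`: 0.147 h
- compound 2 `Cc1cc(C(=O)Nc2ccc(F)cn2)ccc1N(CCN1CCCC1=O)C(=O)Nc1ccc(Cl)cc1`: 0.0617 h
- compound 3 `Cc1cc(C(=O)Nc2ccc(Cl)cc2)ccc1N(CC(=O)N1CCOCC1)C(=O)Nc1ccc(Cl)cc1`: 0.472 h

In an ADME assay on microsomes from liver (Mus musculus) for metabolic stability (on this read-out lower numbers stand for a shorter-lived compound and higher numbers for a longer-lived compound), compound 3 gives 0.472 h, the highest of the three numbers; compound 1 sits nearest with a 3.2-fold higher number from compound 1 to compound 3 (0.51 log units; beyond the scatter) read the other way, and compound 2 furthest.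

Compound 4 `Cc1cc(C(=O)Nc2ccc(Cl)cc2)ccc1N(CCN1CCOCC1=O)C(=O)Nc1ccc(Cl)cc1` has not been measured. It differs from compound 3 by (3-oxomorpholin-4-yl)methyl in place of (morpholin-4-yl)carbonyl on a saturated chain carbon bound to an amide-type nitrogen; the two hold the same atoms, joined differently. Among the measured compounds shown here, the only measured step on this side chain is a 3.2-fold higher number from compound 1 to compound 3 (0.51 log units; beyond the scatter), where (morpholin-4-yl)carbonyl replaced (2-oxopyrrolidin-1-yl)methyl. The group entering compound 4 is named in the same way as the group of compound 1, with a methyl link to a lactam ring, so compound 4 is expected to move back toward compound 1 rather than stay with compound 3. The step of a 2.4-fold lower number from compound 1 to compound 2 (0.38 log units; beyond the scatter) concerns a different position and does not bear on this change.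

Compound 4 is therefore expected to show a 2.4-fold lower number from compound 3 to compound 4 (0.37 log units; beyond the scatter) in this assay. The estimate for compound 4 is 0.2 h, within 0.09 h to 0.45 h.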

Compound 4, half-life: 0.148 h
Compound 4: middle estimate off by 1.4-fold (0.13 log units), on the high side; measured number inside the range.
By their numbers in this assay, from the lowest: compound 2; then compounds 1 and 4 (each within the scatter of the next); then compound 3.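

In this assay, moving the carbonyl out of the chain and into the ring, with the same atoms joined differently, gives a 3.2-fold lower number from compound 3 to compound 4 (0.50 log units; beyond the scatter), so at this position the read-out depends on how the atoms are joined and not only on which atoms are present. Enlarging the lactam ring gives a 1.0-fold higher number from compound 1 to compound 4 (0.00 log units; within the scatter), which is within the scatter, so 3-oxomorpholin-4-yl and 2-oxopyrrolidin-1-yl cannot be told apart on this read-out. No measurement here explains why the two arrangements differ.

Still open, going by these compounds, is whether the longer half-life of compound 3 goes with the carbonyl link on the chain or needs the morpholine ring as well; a (piperidin-1-yl)carbonyl group on that chain carbon would separate the two. On these data alone, the effect of 5-fluoropyridin-2-yl on the core of compound 3 also remains open.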